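A Methyl Added to a Compound at the Assay Limit

This account rests on a few compounds, and the source may have more. Where it says the series, first, only, none or still open, it means among the compounds named here.

Compound 2 has the structure `O=C(Nc1cccc(-c2nc3ccccc3s2)c1)c1cnccc1Cl`. In an ADME assay on BJ cells (Homo sapiens) for inhibition, with a stated time of 72 h (a lower number here means that less compound is needed, a higher number that more compound is needed for the effect), compound 2 gives only a limit, > 25000 nM, not a number. Compound 1, with the structure `O=C(O)/C=C/C(=O)Nc1cccc(-c2nc3ccccc3s2)c1`, also reaches only a limit in this assay, where compound 1 gives > 25000 nM. Among the measured compounds shown here, the single measured step, a step that the two limits leave unreadable from compound 1 to compound 2, therefore cannot be read, since both values sit at the limit of > 25000 nM in this assay, at which 2 of the 2 values shown sit. Compound 3, with the structure `Cc1ccc(-c2nc3ccccc3s2)cc1NC(=O)c1cnccc1Cl`, differs from compound 2 by methyl in place of hydrogen on an aromatic carbon. For the measured compounds named here, no measured step involves a methyl at this place, so the data give no size or direction for such a change. Because compound 2 stands at > 25000 nM, the expectation for compound 3 is a step that the limit leaves unreadable from compound 2 to compound 3, none beyond the scatter. Compound 3 is therefore estimated at 30000 nM, within 8000 nM to 100000 nM.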

Compound 3, half-maximal effective concentration: > 25000 nM
Compound 3 gave a limit, no number (the forecaster's own chance of this, stated with the estimate: 75%); the middle value is on the limit's open side.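

Among the compounds shown here, compound 2 and compound 3 each give only a limit, not a number, so no step between them can be read: the limit of > 25000 nM in this assay, at which 3 of the 3 values shown sit. The compounds shown leave open whether, in this assay, methyl in place of hydrogen on an aromatic carbon changes the concentration needed, and in which direction.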